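Aryl Amine Variation on a Shared Core in Prostate Cells

The source may report more compounds than this note shows. Statements on the series, on what has been measured and on what is new or still open speak of the compounds shown alone.

Compound 1 `C=CC(=O)Nc1cccc(NC(=O)CSc2nc(Nc3ccccc3C)c3ccccc3n2)c1`: 23200 nM
Compound 2 `C=CC(=O)Nc1cccc(NC(=O)CSc2nc(Nc3cccc([N+](=O)[O-])c3)c3ccccc3n2)c1`: 46300 nM
Compound 3 `C=CC(=O)Nc1cccc(NC(=O)CSc2nc(Nc3cccc(OC)c3)c3ccccc3n2)c1`: 34900 nM

Going by the values given here, in a functional assay on PC-3 cells (Homo sapiens) for inhibition, read by MTT assay, with a stated time of 72 h (on this read-out lower numbers stand for stronger inhibition and higher numbers for weaker inhibition), all three numbers lie within the scatter of one another, so no compound can be set apart; compound 3 is separated from its neighbours only by a 1.3-fold lower number from compound 2 to compound 3 (0.12 log units; within the scatter) and by a 1.5-fold higher number from compound 1 to compound 3 (0.18 log units; within the scatter). Compound 4 `C=CC(=O)Nc1cccc(NC(=O)CSc2nc(Nc3ccc(Br)cc3)c3ccccc3n2)c1` differs from compound 3 by 4-bromophenyl in place of 3-methoxyphenyl on a nitrogen on an aromatic ring. Among the compounds with values here, the steps that bear on this change are those that vary the same aryl group on the shared core: a 2.0-fold higher number from compound 1 to compound 2 (0.30 log units; within the scatter), a 1.5-fold higher number from compound 1 to compound 3 (0.18 log units; within the scatter) and a 1.3-fold lower number from compound 2 to compound 3 (0.12 log units; within the scatter), none of which reached beyond the scatter. Compound 4 is therefore expected to return a number of the same order, with no step beyond the scatter in either direction, namely a 1.0-fold higher number from compound 3 to compound 4 (0.00 log units; within the scatter). The estimate for compound 4 is 35000 nM, with a range from 12000 nM to 100000 nM.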

Compound 4, half-maximal inhibitory concentration: 12400 nM
Estimate against measurement, compound 4: 2.8-fold (0.45 log units) above; low and high end bracket the measured number.
By their numbers in this assay, from the lowest: compounds 4, 1, 3 and 2 (each within the scatter of the next, the first and the last beyond it).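

In this assay, going by these compounds alone, 4-bromophenyl on this nitrogen gives the first steps at this position that lie beyond the scatter: a 2.8-fold lower number from compound 3 to compound 4 (0.45 log units; beyond the scatter) and a 3.7-fold lower number from compound 2 to compound 4 (0.57 log units; beyond the scatter) are both modest. Compound 4 does not separate from the 2-methylphenyl compound, with a 1.9-fold lower number from compound 1 to compound 4 (0.27 log units; within the scatter) as the step, so the aryl group matters here only against two of the three earlier groups. Nothing measured here explains these steps.

From the compounds shown here alone, how 4-chlorophenyl, 3-bromophenyl, 4-aminophenyl or 4-carboxyphenyl would compare with 4-bromophenyl on this nitrogen remains open.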